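Moving the fluorine in the compound 3 series

The source may report more compounds than this note shows. Statements on the series, on what has been measured and on what is new or still open speak of the compounds shown alone.

Measured in a functional assay on SW-620 cells (Homo sapiens) for cytotoxicity, read by MTT assay, with stated times of 4 h and 72 h, tested at 2 uM (a lower number here means a stronger inhibitor, a higher number a weaker inhibitor), for three compounds
Compound 1 `Cc1cc(Nc2ccc(C(=O)/C=C/c3ccc(F)cc3)cc2)n2nc(SCc3nc4ccccc4[nH]3)nc2n1` gives 85 nM
Compound 2 `Cc1cc(Nc2ccc(C(=O)/C=C/c3ccc4ccccc4c3)cc2)n2nc(SCc3nc4ccccc4[nH]3)nc2n1` gives 5 nM
Compound 3 `Cc1cc(Nc2ccc(C(=O)/C=C/c3ccccc3F)cc2)n2nc(SCc3nc4ccccc4[nH]3)nc2n1` gives 250 nM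

Compound 3 has the highest number of the three. Compound 4 `Cc1cc(Nc2ccc(C(=O)/C=C/c3cccc(F)c3)cc2)n2nc(SCc3nc4ccccc4[nH]3)nc2n1` carries 3-fluorophenyl in place of 2-fluorophenyl on a double-bonded chain carbon bound to a double-bonded chain carbon and is not yet measured. Within the data shown here, the closest precedent is the modest step of a 2.9-fold higher number from compound 1 to compound 3 (0.47 log units; beyond the scatter) and it also exchanges one fluorophenyl for another. The large steps of a 17-fold lower number from compound 1 to compound 2 (1.23 log units; beyond the scatter) and a 50-fold higher number from compound 2 to compound 3 (1.70 log units; beyond the scatter) involve naphthalen-2-yl and bear less on this change. Expected in this assay is a modest move to a lower number, a 2.3-fold lower number from compound 3 to compound 4 (0.36 log units; beyond the scatter) by estimate. For compound 4 the estimated value is 110 nM within an expected range from 35 nM to 300 nM in this read-out.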

Compound 4, half-maximal inhibitory concentration: 590 nM
The estimate for compound 4 lay 5.4-fold (0.73 log units) below the measured number; measured number above the stated range.
By their numbers in this assay, from the lowest: compound 2; then compound 1; then compound 3; then compound 4.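

Moving the fluorine changes the number at this place in this assay, and 3-fluorophenyl is the weakest of the three fluorophenyl isomers, with a 2.4-fold higher number from compound 3 to compound 4 (0.37 log units; beyond the scatter) and a 6.9-fold higher number from compound 1 to compound 4 (0.84 log units; beyond the scatter). Naphthalen-2-yl remains far ahead of it, with a 120-fold higher number from compound 2 to compound 4 (2.07 log units; beyond the scatter), the widest gap in the series. Nothing measured here accounts for this order of the isomers. Open, as far as these compounds go, is whether 3-chlorophenyl or 3-methoxyphenyl would track 3-fluorophenyl, and whether unsubstituted phenyl sits above or below the fluorophenyl compounds.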